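The source may hold more compounds than are shown below. What is called first, only, known or untested is meant among the compounds shown, and "the series" means these compounds.

Among the measured compounds shown here, in an ADME assay on H9c2 cells (Rattus norvegicus) for cytotoxicity, read by resazurin assay, with a stated time of 72 h (on this read-out higher numbers stand for lower toxicity in this test and lower numbers for higher toxicity in this test), compound 1 `C/C(=N\Nc1nc(C)cs1)c1ccc(Cl)c(Cl)c1` gives 26100 nM and holds the only actual number so far. Compound 2 `C/C(=N\Nc1nc(C)c(C)s1)c1ccc(Cl)c(Cl)c1` reads > 50000 nM as a limit of the assay. Compound 3 `C/C(=N\N=c1\scc(-c2ccccc2)n1C)c1ccc(Cl)c(Cl)c1` reads > 50000 nM as a limit too. Compound 4 `C/C(=N\Nc1nc(-c2ccc(C)cc2)cs1)c1ccc(Cl)c(Cl)c1` differs from compound 1 by 4-methylphenyl in place of methyl on an aromatic carbon on the shared core, with 4-methylphenyl in place of methyl on an aromatic carbon. For the measured compounds named here, the one measured step that bears on this is an at least 1.9-fold higher number from compound 1 to compound 2 (0.28 log units; that floor lies within the scatter) for methyl in place of hydrogen on an aromatic carbon, so no step beyond the scatter is expected in this assay in either direction. Compound 4 may also meet the limit of > 50000 nM in this assay, at which 2 of the 3 values shown sit, as its result. The expected change is a 1.1-fold higher number from compound 1 to compound 4 (0.06 log units; within the scatter) in this estimate. Compound 4 is estimated at 30000 nM with a range of 12000 nM to 60000 nM expected around it.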

Compound 4, half-maximal cytotoxic concentration: > 50000 nM
Compound 4 was reported as a limit; the forecaster's own chance of this, stated with the estimate: 40%; middle value at least 1.6-fold (0.22 log units) from the limit.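

In this assay, among the compounds shown here, the aromatic carbon next to the ring nitrogen, which no earlier step had touched, takes 4-methylphenyl in place of methyl, with an at least 1.9-fold higher number from compound 1 to compound 4 (0.28 log units; that floor lies within the scatter). The result for compound 4 is a limit of the assay, so this step is only a floor: the limit of > 50000 nM in this assay, at which 3 of the 4 values shown sit.

Even so, the added six-membered aromatic ring gives no lower number at this position. From the compounds shown here alone, whether an amine or a carboxylic acid on this carbon would give a measurable number remains open, as does the true size of the step to compound 4.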